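The source may hold more compounds than are shown below. What is called first, only, known or untested is meant among the compounds shown, and "the series" means these compounds.

For the measured compounds named here, in a functional assay, read by spectrophotometry, with a stated time of 1 h (a lower number here means a stronger inhibitor, a higher number a weaker inhibitor), compound 1 `N/N=C/c1cc2ccccc2[nH]c1=O` gives 365000 nM, the lowest of the three numbers measured so far. Compound 2 `Cc1ccc2[nH]c(=O)c(/C=N/N)cc2c1` gives 790000 nM, and compound 3 `CCCC/N=C/c1cc2ccccc2[nH]c1=O` gives 7680000 nM. The first recorded step, methyl in place of hydrogen on an aromatic carbon, is a 2.2-fold higher number from compound 1 to compound 2 (0.34 log units; beyond the scatter). Compound 4 `NS(=O)(=O)CC(=O)N/N=C/c1cc2ccccc2[nH]c1=O` has not yet been measured; it differs from compound 1 by (sulfamoylmethyl)carbonyl in place of hydrogen on an amine nitrogen. The step on the aromatic carbon does not touch this part of the structure. Going by the values given here, the only step that does is the one at the double-bonded nitrogen, butyl in place of amino, which was large: a 21-fold higher number from compound 1 to compound 3 (1.32 log units; beyond the scatter). The change to compound 4 is different in kind, as the amine nitrogen stays in place and one of its hydrogens remains, so a smaller shift is plausible. A weakening of modest size, a 1.6-fold higher number from compound 1 to compound 4 (0.22 log units; within the scatter), is therefore expected in this assay. Compound 4 is expected to give about 600000 nM, within a range from 150000 nM to 3000000 nM.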

Compound 4, half-maximal inhibitory concentration: 8730000 nM
Compound 4: middle estimate off by 15-fold (1.16 log units), on the low side; measured number above the stated range.
By their numbers in this assay, from the lowest: compound 1; then compound 2; then compounds 3 and 4 (each within the scatter of the next).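

Placing (sulfamoylmethyl)carbonyl on the amine nitrogen gives a 24-fold higher number from compound 1 to compound 4 (1.38 log units; beyond the scatter) and so shows that the high number does not depend on losing that nitrogen: it stays in place with one hydrogen left on it, and the number still rises far. Taken with a 21-fold higher number from compound 1 to compound 3 (1.32 log units; beyond the scatter), where the amino group itself gives way to butyl, both changes shown at this end of compound 1 are large steps toward weaker inhibition. For the compounds shown here, nothing available explains why this group raises the number so far.

The compounds shown leave open whether the step comes with the carbonyl on the amine nitrogen or with the sulfamoyl end of the new group. A plain acetyl or a methyl on that nitrogen, or a carboxylic acid in place of the sulfamoyl end, would bear on this question.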